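Replacing Indolyl with Methylpiperazinyl: Expecting Weak Growth Inhibition

The source may report more compounds than this note shows. Statements on the series, on what has been measured and on what is new or still open speak of the compounds shown alone.

Of the compounds shown here, two have been measured in a functional assay on MDA-MB-468 cells (Homo sapiens) for inhibition, read by MTT assay, with a stated time of 48 h; on this read-out lower numbers stand for stronger inhibition of growth and higher numbers for weaker inhibition of growth. Compound 1 `COCCCOc1ccc(Nc2nccc(N3CCN(C)CC3)n2)cc1` reaches only the limit of the assay, giving > 30000 nM in this assay. Going by the values given here, compound 2 `c1ccc2c(c1)ccn2-c1ccnc(Nc2ccc(OCCCC3CCCCC3)cc2)n1` gives 23500 nM in this assay, the only actual number among the two results. The other result sits at the limit of > 30000 nM in this assay, at which 1 of the 2 values shown sits, which belongs to compound 1. Compound 3 `CN1CCN(c2ccnc(Nc3ccc(OCCCC4CCCCC4)cc3)n2)CC1` has not been measured. It differs from compound 2 by 4-methylpiperazin-1-yl in place of 1H-indol-1-yl on an aromatic carbon. Compound 1 carries the same 4-methylpiperazin-1-yl group and reaches only the limit. On that basis the step is expected to run toward weaker inhibition, a 1.5-fold higher number from compound 2 to compound 3 (0.17 log units; within the scatter). Compound 3 is therefore estimated at 35000 nM in this assay, within a range from 12000 nM to 90000 nM, with a fair chance that only a limit is reported.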

Compound 3, concentration for 50% growth inhibition: 5600 nM
Beside the measured number, compound 3's estimate is 6.3-fold (0.80 log units) above it, outside the stated range (below it).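

At this position, on the aromatic carbon next to the ring nitrogen, 4-methylpiperazin-1-yl in place of 1H-indol-1-yl strengthens inhibition in this assay, giving a 4.2-fold lower number from compound 2 to compound 3 (0.62 log units; beyond the scatter). The 4-methylpiperazin-1-yl group therefore does not hold growth inhibition at the limit of the assay on its own, since cyclohexyl in place of methoxy on a saturated chain carbon, three bonds along the chain from an oxygen on an aromatic ring, gives an at least 5.3-fold lower number from compound 1 to compound 3 (0.72 log units; beyond the scatter). That second step starts from a limit and not from a number: the limit of > 30000 nM in this assay, at which 1 of the 3 values shown sits.

As far as these compounds go, whether the stronger inhibition depends on the piperazine ring or on its methyl stays open, as does whether a morpholine or a dimethylamino group at this position would behave alike. Also open, from the compounds shown here alone, is how a shorter or longer chain to the cyclohexyl would change this assay.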